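The source may report more compounds than this note shows. Statements on the series, on what has been measured and on what is new or still open speak of the compounds shown alone.

In a functional assay with Rattus norvegicus as the target (on this read-out lower numbers stand for an effect already at smaller amounts and higher numbers for an effect only at larger amounts of compound), compound 1 `CCCCCCCCC(=O)NCc1ccc(OC)cc1` gives > 100000 nM. That figure is a limit of the assay and not a number. Two other compounds on the shared core do give numbers: compound 2 `CCCCCCCCC(=O)NCc1ccc(O)c(O)c1O` shows 7640 nM and compound 3 `CCCCCCCCC(=O)NCc1ccc([N+](=O)[O-])c(OC)c1` shows 7910 nM. Compound 4 `CCCCCCCCC(=O)NCc1ccc(C(=O)O)cc1` alters compound 1 in one place, with carboxy in place of methoxy on an aromatic carbon, para to a large group: carboxy in place of methoxy on an aromatic carbon. Among the measured compounds shown here, no measured pair shows this change, so any forecast is loose. For the measured compounds named here, the only numbers to lean on are those of compound 2 at 7640 nM and compound 3 at 7910 nM, and compound 4 is not expected to match them. The expected change is an at least 3.3-fold lower number from compound 1 to compound 4 (0.52 log units; beyond the scatter), a modest move towards lower numbers, though a result at the limit would be no surprise. Compound 4 is estimated at 30000 nM, within a range of 8000 nM to 100000 nM.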

Compound 4, half-maximal effective concentration: > 100000 nM
Compound 4 ended at the assay's limit; the forecaster's own chance of this, stated with the estimate: 45%; middle value at least 3.3-fold (0.52 log units) away from the limit.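

Compound 1 and compound 4 both end at a limit rather than a number, so no step between them can be read: the limit of > 100000 nM in this assay, at which 2 of the 4 values shown sit.

As far as these compounds go, whether carboxy in place of methoxy changes the effect at all remains open.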